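The source may report more compounds than this note shows. Statements on the series, on what has been measured and on what is new or still open speak of the compounds shown alone.

In a functional assay on the whole organism for inhibition, with Rattus norvegicus as the target (a lower number here means that less compound is needed, a higher number that more compound is needed for the effect), compound 1, `CCCCSc1nsnc1[C@H]1CN2CCC[C@H]1C2`, gives > 3 mg/kg, which is a limit of the assay and not a number. Compound 2, `CCCCSc1nsnc1[C@@H]1CN2CCC[C@@H]1C2`, gives > 3 mg/kg in this assay, again only a limit. The pair differ in two stereocentres, and the step from compound 1 to compound 2 is a step that the two limits leave unreadable from compound 1 to compound 2, resting on the limit of > 3 mg/kg in this assay, at which 2 of the 3 values shown sit, and on (the fact that one of compounds 1 and 2 is drawn with a defined configuration and the other without, at the place where they differ). Compound 3, `CCCCSc1nsnc1C1CN2CC[C@H]1C2`, gives < 1 mg/kg in this assay, which is also a limit and not a number, so compound 3 stands at the lower edge of what has been seen, as told by the limit of < 1 mg/kg in this assay, at which 1 of the 3 values shown sits.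

Compound 4 is `CCCCSc1nsnc1C1CN2CC[C@@H]1C2`. Against compound 3 the change is the two compounds have the same atoms and bonds; at least one stereo element is drawn with a configuration in one of them and without one in the other: 1 of 3 stereo elements differ; a stereocentre at a saturated ring carbon is drawn R in compound 3 and S in compound 4. Among the compounds with values here, the only measured step that touches a stereocentre, from compound 1 to compound 2, is one that the two limits leave unreadable, so no size and no direction can be taken from it for the present change. With compound 3 itself known only as a limit, the step of an at least 1.5-fold higher number from compound 3 to compound 4 (0.17 log units; that floor lies within the scatter) expected for compound 4 is set with a wide margin and no preferred direction. Compound 4 is therefore estimated at 1.5 mg/kg in this assay, within a range from 0.3 mg/kg to 8 mg/kg.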

Compound 4, dose for half-maximal effect: > 1 mg/kg
Compound 4: a limit, no number; the forecaster's own chance of this, stated with the estimate: 60%; the middle value lies beyond the limit too.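

In this assay, within the data shown here, the single change at a saturated ring carbon, drawn R in compound 3 and S in compound 4, gives a number no lower from compound 3 to compound 4 (the limit leaves the size open), with nothing entering or leaving the structure. Among these compounds, the earlier step at stereocentres, between compound 1 and compound 2, could not be read, so this is the first place where the drawn configuration can be seen to bear on the dose needed, though only in direction and not in size. That reading carries a reservation, since the two compounds are not both fully defined at this place: the fact that one of compounds 3 and 4 is drawn with a defined configuration and the other without, at the place where they differ

From the compounds shown here alone, the size of the step stays open, as compound 3 and compound 4 are each known only as a limit and not as a number. Also open, going by these compounds, is how this assay would respond at this same stereocentre if a longer chain, or an amine, took the place of the butyl chain on the sulfur of the shared core.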